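The source may hold more compounds than are shown below. What is called first, only, known or untested is meant among the compounds shown, and "the series" means these compounds.

Measured compounds:
compound 1, `O=C(O)CCc1cccc2c1B(O)OC2`: > 100000 nM
compound 2, `O=C(CCc1cccc2c1B(O)OC2)Nc1nccs1`: > 100000 nM

In a functional assay on MDA-MB-231 cells (Homo sapiens) for antiproliferative activity, read by MTT assay, with a stated time of 72 h (a lower number here means a stronger inhibitor, a higher number a weaker inhibitor), compound 1 gives only a limit, > 100000 nM. In this assay compound 2 likewise gives only a limit, > 100000 nM. The step that the two limits leave unreadable from compound 1 to compound 2, (1,3-thiazol-2-yl)amino in place of hydroxy on a carbonyl carbon, has no readable size. For the measured compounds named here, compound 2 thus stands at the limit of > 100000 nM in this assay, at which 2 of the 2 values shown sit, where every value so far sits, and no number separates it from compound 1.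

Compound 3, `Cc1ccc(NC(=O)CCc2cccc3c2B(O)OC3)cc1`, differs from compound 2 by 4-methylphenyl in place of 1,3-thiazol-2-yl on an amide-type nitrogen. Going by the values given here, the one measured step, a step that the two limits leave unreadable from compound 1 to compound 2, offers no size to lean on; what is known is only that both measured compounds sit at the limit. Compound 3 is therefore expected to remain near that limit, with a step of a number no higher from compound 2 to compound 3 (the limit leaves the size open) that is not expected to rise above the scatter. Compound 3 is estimated at 100000 nM in this assay, within 20000 nM to 400000 nM, most likely again reported only as a limit.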

Compound 3, half-maximal inhibitory concentration: 1100 nM
Compound 3: middle estimate off by 91-fold (1.96 log units), on the high side, and the stated range ends above it.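

In this assay, the group on the amide-type nitrogen proves able to move the result, since 4-methylphenyl in place of 1,3-thiazol-2-yl gives an at least 90-fold lower number from compound 2 to compound 3 (1.95 log units; beyond the scatter). For the compounds shown here, this is the first step that can be read, and it shows that an amide of the shared core is not tied to the limit, as compound 2 alone might have suggested. Compound 3 is the only one of the three to give a number, while the others give only a limit: the limit of > 100000 nM in this assay, at which 2 of the 3 values shown sit.

The change swaps a five-membered aromatic ring with 2 hetero atoms for a six-membered aromatic ring of carbon only and also brings in the methyl, so the compounds shown do not separate the ring from the methyl. As far as these compounds go, whether a plain phenyl, a 4-chlorophenyl or a longer chain to the amide would hold this activity remains open.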